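Working notes: three carbonyl variants and an isopropylsulfonyl analogue

The compounds below may be only part of what the source reports. "The series", "measured", "known", "first", "only" and "open" are said of these compounds alone.

Measured in an ADME assay on Caco-2 cells (Homo sapiens) for permeability, in the apical to basolateral direction (a higher number here means that the compound crosses the layer faster, a lower number that the compound crosses the layer more slowly), so far:
compound 1, `Cn1cncc1CN1CC(N(CC2CCN(C(=O)c3ccc(Cl)cc3)CC2)S(=O)(=O)c2ccccn2)Cc2cc(C#N)ccc21`: 0.5 10^-6 cm/s
compound 2, `Cn1cncc1CN1CC(N(CC2CCN(C(=O)C(C)(C)C)CC2)S(=O)(=O)c2ccccn2)Cc2cc(C#N)ccc21`: 0.5 10^-6 cm/s
compound 3, `Cn1cncc1CN1CC(N(CC2CCN(C(=O)N3CCCCC3)CC2)S(=O)(=O)c2ccccn2)Cc2cc(C#N)ccc21`: 0.6 10^-6 cm/s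

Compound 3 holds the highest of the three numbers in this assay, but its lead is slight: a 1.2-fold higher number from compound 1 to compound 3 (0.08 log units; within the scatter) and a 1.2-fold higher number from compound 2 to compound 3 (0.08 log units; within the scatter), and no change at the digits printed from compound 1 to compound 2 (within the scatter). All three measured values therefore sit together, and no ordering among them can be read from these figures.

Compound 4, `CC(C)S(=O)(=O)N1CCC(CN(C2Cc3cc(C#N)ccc3N(Cc3cncn3C)C2)S(=O)(=O)c2ccccn2)CC1`, differs from compound 3 at the same position that the three measured compounds vary among themselves: isopropylsulfonyl in place of (piperidin-1-yl)carbonyl on an amine nitrogen in a ring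

The three measured steps are the ones that bear on this change, since each of them swaps the group on that amine nitrogen in the ring. All three stayed within the scatter, even where the group on the carbonyl carbon moved from 4-chlorophenyl to tert-butyl to piperidin-1-yl. None of them, however, replaces a carbonyl-linked group with a sulfonyl-linked one, so the step to compound 4 is only partly covered. On the evidence of compounds 1, 2 and 3, no step beyond the scatter is expected in this assay, in either direction; the estimated step is no change at the digits printed from compound 3 to compound 4 (within the scatter).

Compound 4 is therefore expected to give about 0.6 10^-6 cm/s in this assay, with a range from 0.25 10^-6 cm/s to 1.4 10^-6 cm/s.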

Compound 4, apparent permeability: 0.1 10^-6 cm/s
For compound 4 the middle estimate is 6.0-fold (0.78 log units) above the measured one; measured number outside the range, below it.
By their numbers in this assay, from the lowest: compound 4; then compounds 1, 2 and 3 (each within the scatter of the next).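

In this assay, this position now shows a step beyond the scatter: isopropylsulfonyl on the amine nitrogen in the ring gives a 6.0-fold lower number from compound 3 to compound 4 (0.78 log units; beyond the scatter), a 5.0-fold lower number from compound 2 to compound 4 (0.70 log units; beyond the scatter) and a 5.0-fold lower number from compound 1 to compound 4 (0.70 log units; beyond the scatter). Going by these compounds alone, the same position had tolerated 4-chlorophenyl, tert-butyl and piperidin-1-yl on the carbonyl carbon with every step within the scatter, so the number here is not insensitive to what sits on this nitrogen, and among the four compounds only compound 4, the single sulfonyl-linked member, stands apart. No measurement bears on the origin of this step.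

The change replaces both the linking carbonyl and the group it carries, and one sulfonyl example cannot show whether the lower number goes with the sulfonyl link or with the isopropyl group. Going by these compounds, an isopropylcarbonyl group, a piperidin-1-ylsulfonyl or 4-chlorophenylsulfonyl group, or a plain benzyl group on the same nitrogen would separate these readings, and it remains open whether any of them would stay with compounds 1, 2 and 3 or with compound 4.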